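This account rests on a few compounds, and the source may have more. Where it says the series, first, only, none or still open, it means among the compounds named here.

Working notes on the series. Compound 1 `COCCCn1c(=O)[nH]c2c(N)nc(C(F)(F)F)cc21` carries a 2-methoxyethyl group on the saturated chain carbon bound to the aromatic nitrogen; in a physicochemical assay for lipophilicity (on this read-out lower numbers stand for lower lipophilicity and higher numbers for higher lipophilicity), compound 1 gives 1.9. Compound 2 `Cc1cccc(Cn2c(=O)[nH]c3c(N)nc(C(F)(F)F)cc32)n1` carries a 6-methylpyridin-2-yl group at the same place, and in this assay compound 2 gives 2.3. Among the compounds with values here, the only measured step so far, a number 0.40 log units higher from compound 1 to compound 2 (beyond the scatter), is modest but beyond the scatter, so compound 2 stands highest of the two numbers, with compound 1 as its nearest neighbour.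

Compound 3 `Cc1nc(Cn2c(=O)[nH]c3c(N)nc(C(F)(F)F)cc32)cs1` is not yet measured. Its difference from compound 2 is 2-methyl-1,3-thiazol-4-yl in place of 6-methylpyridin-2-yl on a saturated chain carbon bound to an aromatic nitrogen. Within the data shown here, no measured step exchanges one aromatic ring for another, so the step from compound 1 to compound 2 bears on this change only indirectly, as the sole indication of how much the group at this position moves the read-out. The two rings here are both aromatic and both uncharged, and the change is expected to shift this assay by a number 0.20 log units lower from compound 2 to compound 3 (within the scatter), a step within the scatter or only just beyond it. Compound 3 is therefore expected to give about 2.1, with a range from 1.7 to 2.5.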

Compound 3, distribution coefficient: 2.3
Compound 3: the middle estimate sits 0.20 log units below what was measured; the range from low to high includes it.
By their numbers in this assay, from the lowest: compound 1; then compounds 2 and 3 (each within the scatter of the next).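

In this assay, within the data shown here, the first measured exchange of one aromatic ring for another at this place, 2-methyl-1,3-thiazol-4-yl in place of 6-methylpyridin-2-yl on a saturated chain carbon bound to an aromatic nitrogen, gives no change at the digits printed from compound 2 to compound 3 (within the scatter) despite the change from a six-membered ring with 1 hetero atom to a five-membered ring with 2 hetero atoms. The step away from 2-methoxyethyl now rests on two different rings, since a number 0.40 log units higher from compound 1 to compound 3 (beyond the scatter) is printed at the same size as a number 0.40 log units higher from compound 1 to compound 2 (beyond the scatter) and the read-out at this place therefore does not separate these two aromatic groups. No measurement at hand accounts for either the shared step or the absence of a step between the rings.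

Only two aromatic groups and one open chain are shown at this place, so it remains open whether the match between these two rings extends to other aromatic rings. On these data alone, how a primary amine, a carboxylic acid or a longer chain on the same carbon would read in this assay also remains open.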